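The source may hold more compounds than are shown below. What is called first, only, known or untested is meant among the compounds shown, and "the series" means these compounds.

Working notes on the series. In a functional assay (brain) for inhibition, with Rattus norvegicus as the target (a lower number here means a stronger inhibitor, a higher number a weaker inhibitor), compound 1 `Cc1c(C)c2c(c(C)c1O)CCC(C)(C(=O)[N-][N+](C)(C)C)O2` gives 14000 nM. Compound 2 `Cc1c(C)c2c(c(C)c1O)CC[C@](C)(CC(=O)O)O2` gives 14000 nM in this assay, and compound 3 `Cc1c(C)c2c(c(C)c1O)CC[C@](C)(CC(=O)[N-][N+](C)(C)C)O2` gives 8000 nM. Compound 1 stands level with compound 2 at the digits shown, the two together the highest of the three numbers; its gap to compound 3 is within the scatter. For the measured compounds named here, the only step between two measured compounds that differ in one place is a 1.8-fold lower number from compound 2 to compound 3 (0.24 log units; within the scatter), a group of 5 heavy atoms in place of one oxygen atom on a carbonyl carbon.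

Compound 4 `CSCCC1(C)CCc2c(C)c(O)c(C)c(C)c2O1` differs from compound 1 as follows: a group of 4 heavy atoms (3 carbon, 1 sulfur; no ring) in place of a group of 7 heavy atoms (4 carbon, 2 nitrogen, 1 oxygen; no ring), on a saturated ring carbon. Going by the values given here, no measured step maps onto this change. The step from compound 2 to compound 3 exchanges the end of the chain while the carbonyl remains and stays within the scatter; here the whole chain, carbonyl included, leaves and a 2-(methylsulfanyl)ethyl group enters on the saturated ring carbon. All three measured numbers lie within the scatter of one another, so the make-up of that chain has not yet moved the read-out. On that basis compound 4 is expected to show no step beyond the scatter, with a 1.2-fold lower number from compound 1 to compound 4 (0.07 log units; within the scatter) as the estimated step. For compound 4 the estimate in this assay is 12000 nM, ranging from 4000 nM to 40000 nM.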

Compound 4, half-maximal inhibitory concentration: 3000 nM
The estimate for compound 4 lay 4.0-fold (0.60 log units) above the measured number; measured number outside the range, below it.
By their numbers in this assay, from the lowest: compound 4; then compounds 3, 1 and 2 (each within the scatter of the next).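

For the compounds shown here, the substituent on the saturated ring carbon next to the ring oxygen can move the read-out: in this assay, 2-(methylsulfanyl)ethyl in place of the chain bearing the carbonyl gives a 4.7-fold lower number from compound 1 to compound 4 (0.67 log units; beyond the scatter), the first step beyond the scatter, whereas exchanging only the end of the chain gave a 1.8-fold lower number from compound 2 to compound 3 (0.24 log units; within the scatter). The computed counts of hydrogen-bond donors and acceptors and the net charge are the same for the group that leaves and the group that enters, so these counts do not separate the two compounds. No measurement at hand accounts for the step.

The compounds shown leave open whether the lower number goes with the sulfur atom or with the loss of the carbonyl and the nitrogens, as this change alters them together; a butyl chain, or an ether chain with oxygen in place of sulfur, would separate the two. Also open, as far as these compounds go, is how the number responds to a longer chain, to an amine at the chain end, and to each single stereoisomer at that ring carbon.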